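Moving two chlorines: 2,3-dichlorophenyl to 3,5-dichlorophenyl

The compounds below may be only part of what the source reports. "The series", "measured", "known", "first", "only" and "open" are said of these compounds alone.

Of the compounds shown here, three have been read in an ADME assay on MT4 cells (Homo sapiens) for cytotoxicity, read by MTT assay (on this read-out higher numbers stand for lower toxicity in this test and lower numbers for higher toxicity in this test), so far. Compound 1 (`Cc1ccc(N(C(=O)c2ccccc2C)C(=S)OCCN2C(=O)c3ccccc3C2=O)cc1`) gives > 100000 nM which is a limit and not a number. Compound 2 (`O=C1c2ccccc2C(=O)N1CCOC(=S)N(C(=O)c1ccc(Cl)c(Cl)c1)c1ccccc1`) gives 52000 nM and compound 3 (`O=C1c2ccccc2C(=O)N1CCOC(=S)N(C(=O)c1ccco1)c1cccc(Cl)c1Cl`) gives 100000 nM so these two stand within the scatter of each other. Compound 4 (`O=C1c2ccccc2C(=O)N1CCOC(=S)N(C(=O)c1ccco1)c1cc(Cl)cc(Cl)c1`) carries 3,5-dichlorophenyl in place of 2,3-dichlorophenyl on an amide-type nitrogen and keeps the same atoms, joined differently. Among the compounds with values here, no step between measured compounds speaks to this swap, so no change beyond the scatter is expected in this assay here. The expected size of the move is a 1.4-fold lower number from compound 3 to compound 4 (0.15 log units; within the scatter) and that stays within the scatter. Compound 4 is estimated at 70000 nM with an expected range from 25000 nM to 100000 nM in this read-out.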

Compound 4, half-maximal cytotoxic concentration: > 100000 nM
Compound 4 was reported as a limit; the forecaster's own chance of this, stated with the estimate: 40%; middle value at least 1.4-fold (0.15 log units) away from the limit.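

In this assay, moving the two chlorines on the amide-type nitrogen's phenyl ring gives a number no lower from compound 3 to compound 4 (the limit leaves the size open). Compound 4 gives > 100000 nM, which is a limit and not a number. This is the first direct reading of a change at this position: the new arrangement of the chlorines brings no lower number, but the size of the step cannot be read, and the result joins another at the same limit: the limit of > 100000 nM in this assay, at which 2 of the 4 values shown sit.

Going by these compounds, whether a single chlorine, a methoxy group or an amine on this ring would give a lower number in this assay stays open.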